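Trimming the sulfonyl alkyl chain from compound 2 to compound 4

The source may report more compounds than this note shows. Statements on the series, on what has been measured and on what is new or still open speak of the compounds shown alone.

Measured compounds:
- Compound 1 `O=C([C@@H]1CCCN(S(=O)(=O)c2ccc(S(=O)(=O)N3CC[C@@H](O)C3)cc2)C1)N1CCC(F)(F)CC1`: 330 nM
- Compound 2 `CCC(CC)S(=O)(=O)c1ccc(S(=O)(=O)N2CCC[C@@H](C(=O)N3CCC(F)(F)CC3)C2)cc1`: 40 nM
- Compound 3 `CCN(CC)S(=O)(=O)c1ccc(S(=O)(=O)N2CCC[C@@H](C(=O)N3CCC(C(F)(F)F)CC3)C2)cc1`: 370 nM

Compound 2 stands lowest of the three numbers in a functional assay on BXPC-3 cells (Homo sapiens) for inhibition, read by MTT assay, with a stated time of 7 days; a higher number here means a weaker inhibitor, a lower number a stronger inhibitor. Compound 1 gives 330 nM and compound 3 gives 370 nM, and both steps to compound 2 lie beyond the scatter, so compound 2 is the strongest inhibitor of the three measured.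

Compound 4 `CC(C)S(=O)(=O)c1ccc(S(=O)(=O)N2CCC[C@@H](C(=O)N3CCC(F)(F)CC3)C2)cc1` has not been measured. It differs from compound 2 in one place: isopropyl in place of pentan-3-yl on a sulfonyl sulfur.

Among the measured compounds shown here, only one measured step touches this sulfonyl sulfur: an 8.3-fold lower number from compound 1 to compound 2 (0.92 log units; beyond the scatter). That step exchanged a ring bearing a hydroxyl for the pentan-3-yl chain and gave a clearly lower number. For the measured compounds named here, no step compares two plain alkyl chains of different length at this position, so the size of the change from pentan-3-yl to isopropyl is not read directly from the data. A shorter chain is expected to give at most a small upward move, near the scatter, so compound 4 is estimated at 80 nM (range 30 nM to 250 nM), which means an expected step of a 2.0-fold higher number from compound 2 to compound 4 (0.30 log units; within the scatter).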

Compound 4, half-maximal inhibitory concentration: 50 nM
Estimate against measurement, compound 4: 1.6-fold (0.20 log units) above, and the stated range covers the measured number.
By their numbers in this assay, from the lowest: compounds 2 and 4 (each within the scatter of the next); then compounds 1 and 3 (each within the scatter of the next).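

In this assay, replacing pentan-3-yl with isopropyl gives a 1.3-fold higher number from compound 2 to compound 4 (0.10 log units; within the scatter), so these two plain alkyl groups on the sulfonyl sulfur are not separated by this measurement. The earlier compounds shown here held no such pair of alkyl groups and could not show this. The step of a 6.6-fold lower number from compound 1 to compound 4 (0.82 log units; beyond the scatter) lies beyond the scatter, showing that the lower number relative to 3-hydroxypyrrolidin-1-yl is not confined to pentan-3-yl but also appears with isopropyl.

The compounds shown leave open whether a still shorter chain such as methyl, or a small ring such as cyclopropyl, on this sulfonyl sulfur would stay within the scatter of these two alkyl groups. They also leave open how an amine or a carboxylic acid carried on the alkyl group would read here. No measurement shown offers a reason for either step.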